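Phenyl to chloro on the fused core: working notes

The compounds below may be only part of what the source reports. "The series", "measured", "known", "first", "only" and "open" are said of these compounds alone.

In a functional assay on DU-145 cells (Homo sapiens) for inhibition, read by MTT assay, with a stated time of 48 h; on this read-out higher numbers stand for weaker inhibition and lower numbers for stronger inhibition:
compound 1 `Cc1ccc(-c2nc3ccccn3c2Sc2ccccc2)cc1` gives 83300 nM
compound 2 `c1ccc(Sc2c(-c3ccccc3)nc3ccc(-c4ccccc4)cn23)cc1` gives 71700 nM

Compound 2 holds the lower of the two numbers, but compound 1 sits within the scatter of it, so no order between them is claimed. Compound 3 `Clc1ccc2nc(-c3ccccc3)c(Sc3ccccc3)n2c1` differs from compound 2 by chloro in place of phenyl on an aromatic carbon. For the measured compounds named here, no measured pair shows this change, and nothing here supports a step beyond the scatter in either direction. Compound 3 is expected to give about 80000 nM, with a range of 30000 nM to 200000 nM. The estimated 1.1-fold higher number from compound 2 to compound 3 (0.05 log units; within the scatter) is expected to remain within the scatter.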

Compound 3, half-maximal inhibitory concentration: 56300 nM
Beside the measured number, compound 3's estimate is 1.4-fold (0.15 log units) above it; low and high end bracket the measured number.
By their numbers in this assay, from the lowest: compounds 3, 2 and 1 (each within the scatter of the next).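

For the compounds shown here, at this position, on an aromatic carbon of a six-membered aromatic ring with 1 nitrogen, chloro in place of phenyl gives the only step measured, a 1.3-fold lower number from compound 2 to compound 3 (0.11 log units; within the scatter). In this assay, a single chlorine therefore stands in for a whole phenyl ring with no separable difference in the read-out. No available evidence bears on why the two groups read alike. From the compounds shown here alone, an amine or a carboxylic acid at this position remains open, as does whether any group here moves the number beyond the scatter.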